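Swapping Bromo for Cyano on the Sulfonyl Aryl Ring

This account rests on a few compounds, and the source may have more. Where it says the series, first, only, none or still open, it means among the compounds named here.

Compound 1 `O=C1/C(=C/c2cccnc2)CN(S(=O)(=O)c2ccc(Br)cc2)C/C1=C\c1ccccc1F` carries a bromo group on the aromatic ring that sits on the sulfonyl. In an ADME assay on L02 cells (Homo sapiens) for cytotoxicity, read by MTT assay, with a stated time of 24 h (a lower number here means a stronger inhibitor, a higher number a weaker inhibitor), compound 1 gives 14600 nM. Compound 2 `N#Cc1ccc(S(=O)(=O)N2C/C(=C\c3cccnc3)C(=O)/C(=C/c3ccccc3F)C2)cc1` differs from it in one place only: cyano in place of bromo on an aromatic carbon. In this assay compound 2 gives > 20000 nM, which is a limit of the assay rather than a number. That single change made an at least 1.3-fold higher number from compound 1 to compound 2 (0.13 log units; that floor lies within the scatter).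

Compound 3 `O=C1/C(=C/c2ccncc2)CN(S(=O)(=O)c2ccc(Br)cc2)C/C1=C\c1ccccc1C(F)(F)F` is built on a different core; how its core differs from that of compound 1 is not broken down here. In this assay compound 3 gives 12600 nM, a value that sits within the scatter of compound 1. Compound 4 `N#Cc1ccc(S(=O)(=O)N2C/C(=C\c3ccncc3)C(=O)/C(=C/c3ccccc3C(F)(F)F)C2)cc1` has not yet been measured and differs from compound 3 by the same change: cyano in place of bromo on an aromatic carbon. The place of the change reads the same word for word in both pairs, so this is the same change carried over to a second core; it is seen twice among these compounds.

Since the same change gave an at least 1.3-fold higher number from compound 1 to compound 2 (0.13 log units; that floor lies within the scatter), compound 4 is expected to show a 1.7-fold higher number from compound 3 to compound 4 (0.24 log units; within the scatter) in this assay, with a real chance that only a limit is reported again. The estimate for compound 4 in this assay is 22000 nM, with a range from 11000 nM to 45000 nM.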

Compound 4, half-maximal inhibitory concentration: 17600 nM
For compound 4 the middle estimate is 1.3-fold (0.10 log units) above the measured one; low and high end bracket the measured number.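

Carried to a second core, the change from 4-bromophenyl to 4-cyanophenyl gives a 1.4-fold higher number from compound 3 to compound 4 (0.15 log units; within the scatter) in this assay, so this step alone cannot be told apart from the ordinary spread of repeated measurements. Set side by side, the two cores give no sign that the change behaves differently on one than on the other, but this is weak support for a shared effect, since neither step is shown to be a real change: the same change on two cores in this assay, an at least 1.3-fold higher number (0.13 log units; that floor lies within the scatter) from compound 1 to compound 2 and a 1.4-fold higher number (0.15 log units; within the scatter) from compound 3 to compound 4; the limit leaves it open whether they differ

Compound 2 gives > 20000 nM, which is a limit of the assay and not a number, so these pairs do not show that the change has the same size on both cores: the limit of > 20000 nM in this assay, at which 1 of the 4 values shown sits.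

The compounds shown leave open whether a different group in the same place on the aromatic ring, such as an amine or a carboxylic acid, would give a step beyond the scatter in this assay. They also leave open what the same swap of bromo for cyano would give on a third core, as two cores are too few to set a rule for the series.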